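Sulfanyl-enone series: growth inhibition of DU-145 cells

The source may report more compounds than this note shows. Statements on the series, on what has been measured and on what is new or still open speak of the compounds shown alone.

Measured so far:
compound 1, `CC(=O)c1ccc(/C=C(/Sc2ccc(C)cc2)C(=O)c2ccc(Br)cc2)cc1`: 50000 nM
compound 2, `Cc1ccc(S/C(=C/c2ccc(F)cc2C(F)(F)F)C(=O)c2ccc(Br)cc2)cc1`: 25000 nM

Both values come from a functional assay on DU-145 cells (Homo sapiens) for inhibition, read by trypan blue exclusion, with a stated time of 96 h; a lower number here means a stronger inhibitor of growth, a higher number a weaker inhibitor of growth. In this assay compound 1 gives 50000 nM and compound 2 gives 25000 nM; the two numbers sit within the usual scatter of each other, so compound 2 stands level with compound 1 rather than apart from it, and both are weak inhibitors of growth.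

The next compound is compound 3, `Cc1ccc(S/C(=C/c2ccc(F)cc2F)C(=O)c2ccc(Br)cc2)cc1`. It differs from compound 2 in one place: fluoro in place of trifluoromethyl on an aromatic carbon. Among the compounds with values here, no measured pair shows this kind of exchange, so nothing in the data sets its size. Within the data shown here, with a single weak neighbour and no precedent, the expectation is a step that stays within the scatter, in no fixed direction: a 1.1-fold higher number from compound 2 to compound 3 (0.05 log units; within the scatter) is the expected change from compound 2 to compound 3. Compound 3 is estimated at 28000 nM, with a range from 8000 nM to 90000 nM.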

Compound 3, concentration for 50% growth inhibition: > 100000 nM
Compound 3 gave a limit, no number (the forecaster's own chance of this, stated with the estimate: 20%); middle value at least 3.5-fold (0.55 log units) from the limit.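

In this assay compound 3 gives > 100000 nM, a limit of the assay and not a number. Within the data shown here, this aromatic carbon, ortho to a large group, is the first position where a single exchange reads beyond the scatter: fluoro in place of trifluoromethyl gives an at least 4.0-fold higher number from compound 2 to compound 3 (0.60 log units; beyond the scatter), and that figure is only a floor on the step: the limit of > 100000 nM in this assay, at which 1 of the 3 values shown sits. The other step, with 2,4-difluorophenyl in place of 4-acetylphenyl, gives an at least 2.0-fold higher number from compound 1 to compound 3 (0.30 log units; that floor lies within the scatter), a floor that settles nothing on its own.

Going by these compounds, whether the better reading belongs to trifluoromethyl alone stays open: a methyl, chloro or methoxy group on the same aromatic carbon would test that. The compounds shown also leave open how an amine or a carboxylic acid elsewhere on the shared core would read in this assay.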